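The source may report more compounds than this note shows. Statements on the series, on what has been measured and on what is new or still open speak of the compounds shown alone.

In a functional assay on HeLa cells (Homo sapiens) for antiproliferative activity, read by MTT assay, with a stated time of 48 h (on this read-out lower numbers stand for stronger inhibition and higher numbers for weaker inhibition), compound 3 (`COc1ccc(-c2nn(-c3ccccc3)cc2-c2nc3cc(Cl)ccc3[nH]2)cc1`) gives 1290 nM, the lowest number of the three, against compound 1 (`Fc1ccc(-c2nn(-c3ccccc3)cc2-c2nc3cc(Cl)c(Cl)cc3[nH]2)cc1`) at 11600 nM and compound 2 (`Clc1ccc(-c2nn(-c3ccccc3)cc2-c2nc3cc(Cl)c(Cl)cc3[nH]2)cc1`) at 12100 nM. Compound 4 (`COc1ccc(-c2nn(-c3ccccc3)cc2-c2nc3cc(Cl)c(Cl)cc3[nH]2)cc1`) differs from compound 3 by chloro in place of hydrogen on an aromatic carbon. Among the measured compounds shown here, the only measured step, a 1.0-fold higher number from compound 1 to compound 2 (0.02 log units; within the scatter), is a different change and stays within the scatter, so it does not size this one. Yet compound 1 and compound 2 already hold both chloro groups of compound 4, with fluoro or chloro where it has methoxy, and both show higher numbers. A weaker result is therefore expected, with an estimated step of a 2.7-fold higher number from compound 3 to compound 4 (0.43 log units; beyond the scatter). For compound 4 the estimated value is 3500 nM, with a range of 900 nM to 13000 nM.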

Compound 4, half-maximal inhibitory concentration: 6600 nM
Compound 4: the middle estimate sits 1.9-fold (0.28 log units) below what was measured; the measured number falls inside the stated range.
By their numbers in this assay, from the lowest: compound 3; then compounds 4, 1 and 2 (each within the scatter of the next).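

Placing a chloro group ortho to the existing chloro group raises the number in this assay (a 5.1-fold higher number from compound 3 to compound 4 (0.71 log units; beyond the scatter)), so this position is sensitive to the change. Once both chloro groups are present, methoxy stays within the scatter of chloro (a 1.8-fold lower number from compound 2 to compound 4 (0.26 log units; within the scatter)) and of fluoro (a 1.8-fold lower number from compound 1 to compound 4 (0.24 log units; within the scatter)). No supporting data explain these results.

The compounds shown leave open whether an amine or a carboxylic acid at this position would also raise the number. Also open, going by these compounds, is how fluoro, chloro or a longer chain in place of methoxy would behave without the second chloro group.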